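This account rests on a few compounds, and the source may have more. Where it says the series, first, only, none or still open, it means among the compounds named here.

- Compound 1 `CC(=O)N1CC(CC(=O)NO)(NS(=O)(=O)c2ccc(SCc3cc(C)nc4ccccc34)cc2)C1`: 1000000 nM
- Compound 2 `Cc1cc(COc2ccc(S(=O)(=O)NCCC(=O)NO)cc2)c2ccccc2n1`: 4100000 nM
- Compound 3 `Cc1cc(COc2ccc(S(=O)(=O)NC(C)(C)CC(=O)NO)cc2)c2ccccc2n1`: 1600000 nM

These values come from a physicochemical assay for solubility, with a stated time of 24 h, tested at 30 mg/mL; a higher number here means a more soluble compound, a lower number a less soluble compound. Compound 3 gives 1600000 nM, and this lies within the usual scatter of compound 1 at 1000000 nM. Compound 2 stands clearly higher than either of them.

The next compound to be measured is compound 4 `Cc1cc(COc2ccc(S(=O)(=O)NC3(CC(=O)NO)CC3)cc2)c2ccccc2n1`, which differs from compound 3 in one place: a group of 8 heavy atoms (5 carbon, 1 nitrogen, 2 oxygen; one three-membered non-aromatic ring of carbon only) in place of a group of 8 heavy atoms (5 carbon, 1 nitrogen, 2 oxygen; no ring), on a sulfonamide nitrogen. What is new is the three-membered non-aromatic ring of carbon only.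

Within the data shown here, one measured step bears on this change: a 2.6-fold lower number from compound 2 to compound 3 (0.41 log units; beyond the scatter). It is modest but beyond the scatter, and it sits on the same sulfonamide nitrogen. It is only an indirect guide, however, as it swaps a smaller group for a larger one and adds no ring. Compound 1 differs from compound 3 in more than one place, so it offers no clean comparison.

Among the measured compounds shown here, with no measured step that adds such a ring, the starting point is compound 3 at 1600000 nM, and no clear shift in this assay is expected. The expected change is a 1.1-fold higher number from compound 3 to compound 4 (0.05 log units; within the scatter), which would stay within the scatter. For compound 4 the estimated value is 1800000 nM, with an expected range from 800000 nM to 4000000 nM.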

Compound 4, solubility: 1600000 nM
Estimate against measurement, compound 4: 1.1-fold (0.05 log units) above; the range from low to high includes it.
By their numbers in this assay, from the lowest: compounds 1, 3 and 4 (each within the scatter of the next); then compound 2.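

Replacing the open-chain group on a sulfonamide nitrogen with a group of the same heavy-atom count that contains a three-membered non-aromatic ring of carbon only gives no change at the digits printed from compound 3 to compound 4 (within the scatter) in this assay, so this ring brings no visible shift at this position. Compared with the smaller group of compound 2, the ring-bearing group gives a 2.6-fold lower number from compound 2 to compound 4 (0.41 log units; beyond the scatter), and this matches the earlier open-chain step, a 2.6-fold lower number from compound 2 to compound 3 (0.41 log units; beyond the scatter), so among these three compounds the lower number appears with either of the larger groups, with or without the ring. No measurement offered here explains either the absence of a shift or the lower number relative to compound 2.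

The compounds shown leave open whether a larger carbon ring in the same place, such as a cyclobutane or a cyclohexane, would also stay level with compound 3 and compound 4. They also leave open how this read-out would respond if an amine or a carboxylic acid were attached to the group on the sulfonamide nitrogen, since every group compared here carries neither.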